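Exchanging the aryl amide for a styryl amide in a bis-indole series

A few compounds are considered here, and "the series" means these few. Any claim that something is new, unique, unknown or untested is made for them only; others in the source may bear on it.

Of the compounds shown here, three sharing one core have been measured in a functional assay on HCT-116 cells (Homo sapiens) for cytotoxicity, read by MTT assay, with a stated time of 72 h; a higher number here means a weaker inhibitor, a lower number a stronger inhibitor. Compound 2 `CCc1ccc(C(=O)NC[C@H]2c3[nH]c4ccccc4c3C[C@H]3[C@H]4c5[nH]c6ccccc6c5C[C@@H]([C@H](C#N)N23)N4C)cc1` gives 100 nM, the lowest of the three numbers. Compound 1 `CN1[C@@H]2c3[nH]c4ccccc4c3C[C@H]1[C@H](C#N)N1[C@@H](CNC(=O)c3cccc(C(F)(F)F)c3)c3[nH]c4ccccc4c3C[C@@H]21` gives 630 nM, and compound 3 `CN1[C@@H]2c3[nH]c4ccccc4c3C[C@H]1[C@H](C#N)N1[C@@H](CNC(=O)c3cc4ccccc4[nH]3)c3[nH]c4ccccc4c3C[C@@H]21` gives 880 nM. The steps towards compound 2 are a 6.3-fold lower number from compound 1 to compound 2 (0.80 log units; beyond the scatter) and, away from it, an 8.8-fold higher number from compound 2 to compound 3 (0.94 log units; beyond the scatter), while a 1.4-fold higher number from compound 1 to compound 3 (0.15 log units; within the scatter) separates the other two.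

Compound 4 `CN1[C@@H]2c3[nH]c4ccccc4c3C[C@H]1[C@H](C#N)N1[C@@H](CNC(=O)/C=C/c3ccccc3)c3[nH]c4ccccc4c3C[C@@H]21` is the next variation on the same amide. The change is 2-phenylethenyl in place of 4-ethylphenyl on a carbonyl carbon. Both measured changes of the group on this carbonyl carbon moved away from the 4-ethylphenyl amide of compound 2 and raised the number, by the amounts given for a 6.3-fold lower number from compound 1 to compound 2 (0.80 log units; beyond the scatter) read in reverse and for an 8.8-fold higher number from compound 2 to compound 3 (0.94 log units; beyond the scatter). The 2-phenylethenyl group keeps the same count of heavy atoms and the same aromatic ring but adds a double bond outside the ring; nothing measured here speaks to that particular change. A moderate rise is therefore expected, the estimated step being a 4.0-fold higher number from compound 2 to compound 4 (0.60 log units; beyond the scatter). Compound 4 is expected to give about 400 nM in this assay, with a likely range from 150 nM to 1200 nM.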

Compound 4, half-maximal inhibitory concentration: 1960 nM
Compound 4: middle estimate off by 4.9-fold (0.69 log units), on the low side, outside the stated range (above it).
By their numbers in this assay, from the lowest: compound 2; then compounds 1 and 3 (each within the scatter of the next); then compound 4.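

In this assay the exchange of 4-ethylphenyl for 2-phenylethenyl keeps the heavy-atom count and the aromatic ring, yet it brings a 20-fold higher number from compound 2 to compound 4 (1.29 log units; beyond the scatter) and is the largest step seen at this carbonyl carbon. The new amide also stands apart from the other two, with a 3.1-fold higher number from compound 1 to compound 4 (0.49 log units; beyond the scatter) and a 2.2-fold higher number from compound 3 to compound 4 (0.35 log units; beyond the scatter), so all three earlier groups give lower numbers than 2-phenylethenyl. The earlier compounds shown here spanned a narrower range, and compound 4 widens it at the upper end.

Nothing available explains this rise. The compounds shown leave open whether the double bond outside the ring matters on its own, and how a saturated 2-phenylethyl group, an unsubstituted phenyl or a phenyl ring carrying an amine would read at this carbonyl carbon.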